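Fluoro to chloro on the sulfonyl aryl of compound 3

A few compounds are considered here, and "the series" means these few. Any claim that something is new, unique, unknown or untested is made for them only; others in the source may bear on it.

The measured compounds:
compound 1, `O=C1O/C(=C\Cn2cc(-c3ccc(Br)cc3)nn2)C(OCc2ccccc2)=C1OCc1ccccc1`, > 100000 nM (a limit of the assay)
compound 2, `COc1ccccc1-c1cn(C[C@H](O)[C@H]2OC(=O)C(OCc3ccccc3)=C2OCc2ccccc2)nn1`, > 100000 nM (a limit of the assay)
compound 3, `O=C1O[C@H]([C@@H](O)Cn2cc(CNS(=O)(=O)c3ccc(F)cc3)nn2)C(OCc2ccccc2)=C1OCc1ccccc1`, 22500 nM

In a functional assay on A549 cells (Homo sapiens) for antiproliferative activity, read by MTT assay, with a stated time of 72 h (on this read-out higher numbers stand for weaker inhibition and lower numbers for stronger inhibition), compound 1 reaches only a limit, > 100000 nM. Compound 2 likewise gives only a limit in this assay, > 100000 nM. For the measured compounds named here, compound 3 is the one compound with a number in this assay, 22500 nM, and it is placed against (the limit of > 100000 nM in this assay, at which 2 of the 3 values shown sit). Going by the values given here, the single measured step, an at least 4.4-fold lower number from compound 2 to compound 3 (0.64 log units; beyond the scatter), is a large change of the group on the triazole and does not involve a halogen swap.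

Compound 4, `O=C1O[C@H]([C@@H](O)Cn2cc(CNS(=O)(=O)c3ccc(Cl)cc3)nn2)C(OCc2ccccc2)=C1OCc1ccccc1`, differs from compound 3 by chloro in place of fluoro on an aromatic carbon. Among the compounds with values here, no measured step covers an exchange of this kind, so there is no basis for expecting a change beyond the scatter. The estimated step of a 1.3-fold lower number from compound 3 to compound 4 (0.10 log units; within the scatter) is therefore expected to be small. For compound 4 the expected value in this assay is 18000 nM, with a range from 7000 nM to 45000 nM.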

Compound 4, half-maximal inhibitory concentration: 2870 nM
Compound 4: middle estimate off by 6.3-fold (0.80 log units), on the high side; the measured number lies below the stated range.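

In this assay, for the compounds shown here, chloro in place of fluoro on an aromatic carbon, para to a large group, gives a 7.8-fold lower number from compound 3 to compound 4 (0.89 log units; beyond the scatter), so a change of one heavy atom at this place moves the read-out beyond the scatter, which the earlier compounds could not show. With chloro at this place, exchanging the group on the aromatic carbon gives an at least 34-fold lower number from compound 2 to compound 4 (1.54 log units; beyond the scatter), a wider step than the one seen with fluoro, an at least 4.4-fold lower number from compound 2 to compound 3 (0.64 log units; beyond the scatter). Compound 2 stands at a limit of the assay and not at a number, so both steps from it are bounds only: the limit of > 100000 nM in this assay, at which 2 of the 4 values shown sit.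

The compounds shown hold only fluoro and chloro at this place, so whether bromo, methyl or methoxy there would give a lower or a higher number stays open. Also open, as far as these compounds go, is whether the sulfonyl amino link is needed, or whether a carboxamide could take its place.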